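Swapping the Ketone Aryl Group on a Quinoline Chalcone Scaffold

This account rests on a few compounds, and the source may have more. Where it says the series, first, only, none or still open, it means among the compounds named here.

Measured compounds in a functional assay on SK-BR-3 cells (Homo sapiens) for antiproliferative activity, read by XTT assay, with a stated time of 72 h; on this read-out lower numbers stand for stronger inhibition and higher numbers for weaker inhibition:
- compound 1, `COc1ccc(-c2cc3ccccc3nc2/C=C/C(=O)c2c(OC)cccc2OC)cc1`: 3830 nM
- compound 2, `COc1ccc(-c2cc3ccccc3nc2/C=C/C(=O)c2ccc([N+](=O)[O-])cc2)cc1`: 590 nM
- compound 3, `COc1ccc(-c2cc3ccccc3nc2/C=C/C(=O)c2ccsc2)cc1`: 660 nM

Compound 1 gives the highest number of the three, so it is the weakest inhibitor in this assay. The two other compounds share its core and differ only in the group attached to the carbonyl carbon. Moving to the 4-nitrophenyl gave a 6.5-fold lower number from compound 1 to compound 2 (0.81 log units; beyond the scatter), and moving to the thiophen-3-yl gave a 5.8-fold lower number from compound 1 to compound 3 (0.76 log units; beyond the scatter); the two replacement groups themselves sit close together, as a 1.1-fold higher number from compound 2 to compound 3 (0.05 log units; within the scatter) shows.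

Compound 4, `COc1ccc(-c2cc3ccccc3nc2/C=C/C(=O)c2cnc(N)nc2C)cc1`, is not yet measured. Its change from compound 1 is 2-amino-4-methylpyrimidin-5-yl in place of 2,6-dimethoxyphenyl on a carbonyl carbon. Both earlier replacements of the 2,6-dimethoxyphenyl on the carbonyl carbon lowered the number well beyond the scatter, and by a similar amount, so a further aryl swap of this kind is expected to act in the same direction, though the new group is unlike either tested one. The expected step is therefore a 4.3-fold lower number from compound 1 to compound 4 (0.63 log units; beyond the scatter). For compound 4 the estimate in this assay is 900 nM, within a range from 300 nM to 3500 nM.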

Compound 4, half-maximal inhibitory concentration: > 10000 nM
Compound 4: a limit, no number; the forecaster's own chance of this, stated with the estimate: 5%; middle value at least 11-fold (1.04 log units) away from the limit.
By their numbers in this assay, from the lowest: compounds 2 and 3 (each within the scatter of the next); then compound 1. At a limit, above all of these: compound 4.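

In this assay compound 4 gives > 10000 nM, which is a limit of the assay and not a number. The earlier compounds shown here showed only gains on replacing the 2,6-dimethoxyphenyl, but this position on the carbonyl carbon can also lose activity, since the new group gives an at least 2.6-fold higher number from compound 1 to compound 4 (0.41 log units; beyond the scatter). Compared with the two groups that improved on compound 1, the drop is large: an at least 15-fold higher number from compound 3 to compound 4 (1.18 log units; beyond the scatter), and an at least 16-fold higher number from compound 2 to compound 4 (1.22 log units; beyond the scatter).

The 2-amino-4-methylpyrimidin-5-yl brings an amine, a methyl and ring nitrogens all at once, so the compounds shown cannot say which of these parts goes with the loss. A pyrimidin-5-yl with no amine, or a plain phenyl, on the same carbonyl carbon would help to separate them.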